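Replacing the Pyrrolidinylmethyl Group with Acetyl

This account rests on a few compounds, and the source may have more. Where it says the series, first, only, none or still open, it means among the compounds named here.

Measured compounds:
compound 1 `CCC(C)[C@H](NCC1CCCO1)c1cc(C(F)(F)F)ccc1N1CCN(C(=O)CCc2ccc(Cl)cc2Cl)CC1`: 780 nM
compound 2 `CCC(C)[C@H](NC[C@H]1CCCN1)c1cc(C(F)(F)F)ccc1N1CCN(C(=O)CCc2ccc(Cl)cc2Cl)CC1`: 110 nM

Of the compounds shown here, two have been measured in an assay on HEK293 cells for displacement of a labelled ligand from Melanocortin receptor 4 (Homo sapiens); on this read-out lower numbers stand for stronger inhibition and higher numbers for weaker inhibition. Compound 1 `CCC(C)[C@H](NCC1CCCO1)c1cc(C(F)(F)F)ccc1N1CCN(C(=O)CCc2ccc(Cl)cc2Cl)CC1` gives 780 nM, and compound 2 `CCC(C)[C@H](NC[C@H]1CCCN1)c1cc(C(F)(F)F)ccc1N1CCN(C(=O)CCc2ccc(Cl)cc2Cl)CC1` gives 110 nM. Among the compounds with values here, the single measured step is a 7.1-fold lower number from compound 1 to compound 2 (0.85 log units; beyond the scatter); compound 2 therefore stands as the lower of the two numbers, and the gap to compound 1 lies beyond the scatter.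

Compound 3 `CCC(C)[C@H](NC(C)=O)c1cc(C(F)(F)F)ccc1N1CCN(C(=O)CCc2ccc(Cl)cc2Cl)CC1` differs from compound 2 in one place: acetyl in place of (pyrrolidin-2-yl)methyl on an amine nitrogen. Within the data shown here, no measured step covers this change directly. The step from compound 1 to compound 2 bears on it only loosely: there, one five-membered ring replaced another; here the ring leaves altogether and a carbonyl enters. With the group that accompanied the lower number in this assay removed, a rise in number is expected, estimated as a 14-fold higher number from compound 2 to compound 3 (1.13 log units; beyond the scatter). Compound 3 is thus expected to give 1500 nM, within a range of 400 nM to 6000 nM.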

Compound 3, inhibition constant: 360 nM
Estimate against measurement, compound 3: 4.2-fold (0.62 log units) above, outside the stated range (below it).
By their numbers in this assay, from the lowest: compound 2; then compound 3; then compound 1.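

In this assay, acetyl in place of (pyrrolidin-2-yl)methyl on the amine nitrogen gives a 3.3-fold higher number from compound 2 to compound 3 (0.51 log units; beyond the scatter), so the lowest number remains with the pyrrolidine-bearing compound, yet a group with no ring still reaches a number that is only modestly higher. Acetyl also compares well with the other ring-bearing group, giving a 2.2-fold lower number from compound 1 to compound 3 (0.34 log units; beyond the scatter), so across these three compounds a ring on this side chain does not by itself bring a lower number: compound 1 has one and stands highest. No measurement shown explains this order of the three groups.

From the compounds shown here alone, it remains open whether the pyrrolidine ring or simply a nitrogen in that group matters, which an open-chain 2-aminoethyl group on the same nitrogen could help separate. It is also unclear how a longer acyl chain, such as propanoyl, would compare with acetyl.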